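Removing one isobutyl ether from the bis-ether nucleoside

A few compounds are considered here, and "the series" means these few. Any claim that something is new, unique, unknown or untested is made for them only; others in the source may bear on it.

Going by the values given here, compound 2 `CC(C)COC[C@@]1(N=[N+]=[N-])O[C@@H](n2ccc(N)nc2=O)[C@H](C)[C@@H]1OCC(C)C` sits at the upper edge of the numbers so far. In an in vitro ADME assay on microsomes from liver (Homo sapiens) for metabolic stability (on this read-out lower numbers stand for slow clearance and higher numbers for fast clearance), compound 2 gives > 300 mL.min-1.g-1, which is a limit of the assay and not a number, as noted in the limit of > 300 mL.min-1.g-1 in this assay, at which 1 of the 2 values shown sits. Compound 1 `C[C@H]1[C@H](n2ccc(N)nc2=O)O[C@@](CO)(N=[N+]=[N-])[C@H]1O`, carrying two free hydroxyls on the same core, sits at the other end: in this assay compound 1 gives < 6 mL.min-1.g-1, again a limit rather than a number, as noted in the limit of < 6 mL.min-1.g-1 in this assay, at which 1 of the 2 values shown sits. Compound 3 `CC(C)CO[C@H]1[C@@H](C)[C@H](n2ccc(N)nc2=O)O[C@@]1(CO)N=[N+]=[N-]` differs from compound 2 by hydrogen in place of isobutyl on an oxygen on a saturated carbon, so one isobutoxy becomes hydroxy while the other isobutoxy remains. Among the compounds with values here, no measured step covers this change. A move toward slower clearance is expected, clearly beyond the scatter, with the expected step of an at least 5.0-fold lower number from compound 2 to compound 3 (0.69 log units; beyond the scatter). Compound 3 is therefore estimated at 60 mL.min-1.g-1 in this assay, within a range from 15 mL.min-1.g-1 to 300 mL.min-1.g-1.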

Compound 3, intrinsic clearance in microsomes: 12 mL.min-1.g-1
Compound 3: the middle estimate sits 5.0-fold (0.70 log units) above what was measured; the whole stated range lies above it.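

In this assay, hydrogen in place of isobutyl on an oxygen on a saturated carbon, here (isobutoxy)methyl to hydroxymethyl, gives an at least 25-fold lower number from compound 2 to compound 3 (1.39 log units; beyond the scatter), so this single change is enough to bring the read-out off the upper limit. Read from the other side, isobutyl in place of hydrogen gives an at least 2.0-fold higher number from compound 1 to compound 3 (0.30 log units; that floor lies within the scatter), and with that floor within the scatter, the isobutoxy kept in compound 3 is not shown to raise the number. Each step is a floor and not a size, as one end of each is a limit of the assay.

From the compounds shown here alone, whether exchanging the other isobutoxy for hydroxy would give a like step stays open. Also open, going by these compounds, is how a methoxy, a longer chain or an amine in place of the isobutoxy would read in this assay.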